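The source may report more compounds than this note shows. Statements on the series, on what has been measured and on what is new or still open speak of the compounds shown alone.

Measured compounds and their values:
- compound 1, `Cc1nc(-c2ccccc2)sc1COc1ccc(S(=O)(=O)CC(=O)O)cc1`: in a functional assay on CHO cells for agonist activity at Free fatty acid receptor 1 (Homo sapiens), read by FLIPR and calcium flux (on this read-out higher numbers stand for an effect only at larger amounts of compound and lower numbers for an effect already at smaller amounts), compound 1 gives 331 nM
- compound 2, `Cc1nc(-c2ccccc2F)sc1COc1ccc(S(=O)(=O)CC(=O)O)cc1`: in this assay compound 2 gives 550 nM

Among the measured compounds shown here, compound 2 has the higher of the two numbers, yet its only neighbour, compound 1, sits close by, with a 1.7-fold higher number from compound 1 to compound 2 (0.22 log units; within the scatter); the two are therefore not separated beyond the usual scatter, and no order between them is claimed.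

Compound 3, `Cc1nc(-c2cccc(F)c2)sc1COc1ccc(S(=O)(=O)CC(=O)O)cc1`, is the next compound to be measured. It differs from compound 2 in a single place: 3-fluorophenyl in place of 2-fluorophenyl on an aromatic carbon. For the measured compounds named here, the only measured step that touches this part of the molecule is the one from compound 1 to compound 2, in which a fluorine was placed on the phenyl ring; its size, a 1.7-fold higher number from compound 1 to compound 2 (0.22 log units; within the scatter), is within the scatter. Going by the values given here, no measured pair shows the fluorine moved from one ring position to another, so the data give no direct guide to such a shift. On that basis no step beyond the scatter is expected from compound 2 to compound 3, and the expected change amounts to a 1.2-fold lower number from compound 2 to compound 3 (0.09 log units; within the scatter). Compound 3 is therefore estimated at 450 nM, with a likely range from 150 nM to 1400 nM.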

Compound 3, half-maximal effective concentration: 275 nM
Compound 3: middle estimate off by 1.6-fold (0.21 log units), on the high side; low and high end bracket the measured number.
By their numbers in this assay, from the lowest: compounds 3, 1 and 2 (each within the scatter of the next).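

With the fluorine moved for the first time, a 2.0-fold lower number from compound 2 to compound 3 (0.30 log units; within the scatter) in this assay, so the change from 2-fluorophenyl to 3-fluorophenyl is not separated from the usual variation between repeat measurements, even though it is the largest step among these three compounds. The new comparison with the unsubstituted phenyl ring gives a 1.2-fold lower number from compound 1 to compound 3 (0.08 log units; within the scatter) and also stays within the scatter, so neither fluorinated compound can be told apart from compound 1, and these three compounds show no effect of either adding this fluorine or shifting it between these two ring positions. No independent measurement is available that could explain the small differences among these numbers.

Still open is whether a larger group on this phenyl ring, such as chloro, methoxy or trifluoromethyl, would produce a step beyond the scatter, since fluorine is the only substituent shown there. The compounds shown also leave open how an ethyl group in place of the methyl on the five-membered ring, or an amide in place of the carboxylic acid, would alter the number.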